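The source may hold more compounds than are shown below. What is called first, only, known or untested is meant among the compounds shown, and "the series" means these compounds.

Measured compounds in an ADME assay on RAW264.7 cells (Mus musculus) for cytotoxicity, read by MTT assay, with a stated time of 48 h; a higher number here means that more compound is tolerated, a lower number that less compound is tolerated:
- compound 1 `C=CCNC(=S)N/N=C\c1ccnc2ccccc12`: 105000 nM
- compound 2 `O=[N+]([O-])c1ccc(NC(=S)N/N=C\c2ccnc3ccccc23)cc1`: 82500 nM
- compound 3 `S=C(N/N=C\c1ccnc2ccccc12)Nc1ccc(Br)cc1`: 53500 nM

Compound 1 carries the highest of the three numbers, yet the gaps to the other two stay within the scatter: compound 2 gives 82500 nM and compound 3 gives 53500 nM, both close to the value of compound 1.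

Compound 4 `S=C(N/N=C\c1ccnc2ccccc12)Nc1ccc(Cl)cc1` is not yet measured. It differs from compound 1 as follows: 4-chlorophenyl in place of allyl on an amide-type nitrogen.

Going by the values given here, only one measured step bears on this change, the one with 4-bromophenyl in the same place: a 2.0-fold lower number from compound 1 to compound 3 (0.29 log units; within the scatter). The step from compound 2 to compound 3, a 1.5-fold lower number from compound 2 to compound 3 (0.19 log units; within the scatter), concerns the substituent on the aromatic ring and is of the same modest size. Neither step leaves the scatter, so for compound 4 no shift beyond the scatter is expected in this assay, at most a small move toward a lower number.

Compound 4 is therefore estimated at 60000 nM, with a range from 30000 nM to 120000 nM; this means an expected step of a 1.8-fold lower number from compound 1 to compound 4 (0.24 log units; within the scatter).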

Compound 4, half-maximal cytotoxic concentration: 63500 nM
Compound 4: middle estimate off by 1.1-fold (0.02 log units), on the low side, and the stated range covers the measured number.
By their numbers in this assay, from the lowest: compounds 3, 4, 2 and 1 (each within the scatter of the next).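

In this assay, 4-chlorophenyl in place of allyl on the amide-type nitrogen gives a 1.7-fold lower number from compound 1 to compound 4 (0.22 log units; within the scatter), so a second halogen-bearing phenyl group at this position also stays within the scatter of the allyl compound. Going by these compounds alone, on the aromatic carbon, chloro in place of bromo gives a 1.2-fold higher number from compound 3 to compound 4 (0.07 log units; within the scatter) and chloro in place of nitro gives a 1.3-fold lower number from compound 2 to compound 4 (0.11 log units; within the scatter), so these three substituents are not separated in this assay, and no step among the four compounds leaves the scatter. No measurement bearing on the cause of these small steps is available.

From the compounds shown here alone, whether any group on the amide-type nitrogen can move the number beyond the scatter remains open. A dimethylamino or carboxylic acid group on the phenyl ring, or a longer chain in place of allyl, could test this in this assay.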